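Triazolylmethyl dithiocarbamate series: benzyl substitution step

The compounds below may be only part of what the source reports. "The series", "measured", "known", "first", "only" and "open" are said of these compounds alone.

Measured compounds:
- compound 1 `COc1ccc(-n2cc(CSC(=S)N3CCN(C(=O)OC(C)(C)C)CC3)nn2)cc1`, 93100 nM
- compound 2 `Cc1ccc(Cn2cc(CSC(=S)N3CCN(C(=O)OC(C)(C)C)CC3)nn2)cc1`, 19700 nM
- compound 3 `CC(C)(C)OC(=O)N1CCN(C(=S)SCc2cn(Cc3ccc(Cl)c(Cl)c3)nn2)CC1`, 19100 nM

All three were read in a functional assay on MCF7 cells (Homo sapiens) for inhibition, read by MTT assay, with a stated time of 72 h; on this read-out lower numbers stand for stronger inhibition and higher numbers for weaker inhibition. Compound 1, with a 4-methoxyphenyl directly on the aromatic nitrogen, gives the highest number; the two benzyl compounds sit together at the low end, compound 3 and compound 2 being within the scatter of each other (a 1.0-fold lower number from compound 2 to compound 3 (0.01 log units; within the scatter)). The steps from the aryl compound to the benzyl compounds were both modest: a 4.7-fold lower number from compound 1 to compound 2 (0.67 log units; beyond the scatter) and a 4.9-fold lower number from compound 1 to compound 3 (0.69 log units; beyond the scatter).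

Compound 4 `CC(C)(C)OC(=O)N1CCN(C(=S)SCc2cn(Cc3ccccc3Cl)nn2)CC1` is not yet measured. It differs from compound 3 as follows: 2-chlorophenyl in place of 3,4-dichlorophenyl on a saturated chain carbon bound to an aromatic nitrogen. Among the measured compounds shown here, the only measured step that bears on this is the exchange of ring substituents on the benzyl group, from compound 2 to compound 3, which stayed within the scatter. For the measured compounds named here, no measured step changes the number of chlorines or their ring positions on this benzyl group, so the direction is open. The expectation is therefore no change beyond the scatter in this assay, a 1.2-fold higher number from compound 3 to compound 4 (0.06 log units; within the scatter). For compound 4 the estimated value is 22000 nM, with a range from 8000 nM to 60000 nM.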

Compound 4, half-maximal inhibitory concentration: 6090 nM
Compound 4: the middle estimate sits 3.6-fold (0.56 log units) above what was measured, and the stated range ends above it.
By their numbers in this assay, from the lowest: compound 4; then compounds 3 and 2 (each within the scatter of the next); then compound 1.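

In this assay the benzyl ring no longer looks indifferent to its substituents: 2-chlorobenzyl stands apart, with a 3.1-fold lower number from compound 3 to compound 4 (0.50 log units; beyond the scatter) and a 3.2-fold lower number from compound 2 to compound 4 (0.51 log units; beyond the scatter), whereas the exchange between compounds 2 and 3 stayed within the scatter. Among the compounds shown here, the distance to the directly attached 4-methoxyphenyl group also grows to a 15-fold lower number from compound 1 to compound 4 (1.18 log units; beyond the scatter), the only step in this set printed as large. Going from 3,4-dichlorobenzyl to 2-chlorobenzyl alters the number of chlorines and their placement together, the compounds shown do not separate these two changes, and no supporting measurement is available to explain the result.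

Whether the lower number requires a chlorine at all remains open, with no plain benzyl group among these compounds. Also open, on these data alone, is how an amine or a carboxylic acid on this ring would read out.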